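From arylthio to tert-butoxy at the same aromatic carbon

The compounds below may be only part of what the source reports. "The series", "measured", "known", "first", "only" and "open" are said of these compounds alone.

Measured compounds:
compound 1 `Cc1cc(-c2ccc(Cl)cc2)c(S(C)(=O)=O)cc1C(=O)N=C(N)N` — 45 nM
compound 2 `Cc1cc(-c2ccc(F)cc2)c(S(C)(=O)=O)cc1C(=O)N=C(N)N` — 36 nM
compound 3 `Cc1cc(Sc2ccccc2Cl)c(S(C)(=O)=O)cc1C(=O)N=C(N)N` — 14 nM

In a functional assay for inhibition of sodium/hydrogen exchanger (Oryctolagus cuniculus) (a higher number here means a weaker inhibitor, a lower number a stronger inhibitor), compound 3 gives the lowest number of the three. The gap is set by the steps of a 3.2-fold lower number from compound 1 to compound 3 (0.51 log units; beyond the scatter) and a 2.6-fold lower number from compound 2 to compound 3 (0.41 log units; beyond the scatter), both modest but beyond the scatter. The remaining step, a 1.3-fold lower number from compound 1 to compound 2 (0.10 log units; within the scatter), shows that exchanging one halogen for the other on the aryl group changes little.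

Compound 4 `Cc1cc(OC(C)(C)C)c(S(C)(=O)=O)cc1C(=O)N=C(N)N` carries a different group at the same place: tert-butoxy in place of (2-chlorophenyl)sulfanyl on an aromatic carbon. For the measured compounds named here, no measured pair describes an exchange of this kind; the two steps that do touch this position show that changes there move the number modestly. Going by the values given here, with the ring-bearing group of compound 3 gone and no precedent for tert-butoxy, a modest rise in the number, toward the region of compounds 1 and 2 or somewhat beyond, is expected rather than a further fall. Compound 4 is therefore estimated at 60 nM, with a range of 15 nM to 250 nM, which corresponds to an expected step of a 4.3-fold higher number from compound 3 to compound 4 (0.63 log units; beyond the scatter).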

Compound 4, half-maximal inhibitory concentration: 9.4 nM
Compound 4: the middle estimate sits 6.4-fold (0.81 log units) above what was measured; the whole stated range lies above it.
By their numbers in this assay, from the lowest: compounds 4 and 3 (each within the scatter of the next); then compounds 2 and 1 (each within the scatter of the next).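

In this assay the step of a 1.5-fold lower number from compound 3 to compound 4 (0.17 log units; within the scatter) shows that this position does not need an aromatic ring to give a low number: tert-butoxy, with no ring, stands level with (2-chlorophenyl)sulfanyl. The steps of a 3.8-fold lower number from compound 2 to compound 4 (0.58 log units; beyond the scatter) and a 4.8-fold lower number from compound 1 to compound 4 (0.68 log units; beyond the scatter) place tert-butoxy clearly apart from 4-fluorophenyl and 4-chlorophenyl, so among these four compounds the two groups joined through oxygen or sulfur, in compound 3 and compound 4, give lower numbers than the two aryl groups joined directly. Nothing at hand accounts for this result. The compounds shown leave open how a methoxy group, a longer unbranched alkoxy chain or an amine would read at this aromatic carbon. They also leave open whether the branching of tert-butoxy matters at all.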